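A few compounds are considered here, and "the series" means these few. Any claim that something is new, unique, unknown or untested is made for them only; others in the source may bear on it.

Measured compounds:
compound 1 `O=C(Nc1cccc(-c2nc(-c3ccc(NC(=O)c4cccnc4)cc3Cl)no2)c1)c1ccccc1` gives 12800 nM
compound 2 `O=C(Nc1cccc(-c2nc(-c3ccc(NC(=O)c4cccnc4)cc3Cl)no2)c1)Nc1ccc(Cl)c(C(F)(F)F)c1` gives 1900 nM
compound 3 `C#Cc1cccc(NC(=O)Nc2cccc(-c3nc(-c4ccc(NC(=O)c5cccnc5)cc4Cl)no3)c2)c1` gives, as a limit of the assay, > 10000 nM

In a functional assay on MDA-MB-231 cells (Homo sapiens) for antiproliferative activity, read by MTT assay, with a stated time of 72 h (a higher number here means a weaker inhibitor, a lower number a stronger inhibitor), compound 2 stands lowest of the two numbers shown; the nearest is compound 1, reached by a 6.7-fold lower number from compound 1 to compound 2 (0.83 log units; beyond the scatter). Compound 3 sits at a limit (the limit of > 10000 nM in this assay, at which 1 of the 3 values shown sits), so the step of an at least 5.2-fold higher number from compound 2 to compound 3 (0.72 log units; beyond the scatter) is readable only as a lower bound.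

Compound 4 `CS(=O)(=O)Nc1ccc(NC(=O)Nc2cccc(-c3nc(-c4ccc(NC(=O)c5cccnc5)cc4Cl)no3)c2)cc1C(F)(F)F` differs from compound 2 by methanesulfonamido in place of chloro on an aromatic carbon. For the measured compounds named here, no measured step exchanges a single group at this place; the two measured steps swap the whole aryl on the urea nitrogen and were at least modest. The methanesulfonamido change is therefore expected to give a step of a 1.6-fold higher number from compound 2 to compound 4 (0.20 log units; within the scatter). Compound 4 is expected to give about 3000 nM, within 800 nM to 12000 nM.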

Compound 4, half-maximal inhibitory concentration: 700 nM
Compound 4: the middle estimate sits 4.3-fold (0.63 log units) above what was measured, and the stated range ends above it.
By their numbers in this assay, from the lowest: compound 4; then compound 2; then compound 1.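

Unlike the earlier steps, which swap the whole aryl on the urea nitrogen, this one exchanges a single group on that ring. In this assay, methanesulfonamido in place of chloro gives a 2.7-fold lower number from compound 2 to compound 4 (0.43 log units; beyond the scatter), so this place, ortho to a trifluoromethyl group, tolerates a larger group carrying a hydrogen-bond donor, and the number improves. Nothing measured here accounts for the gain.

From the compounds shown here alone, whether an amine or a carboxylic acid at this place would do the same stays open, as does a longer chain on the sulfonyl. Going by these compounds, whether the trifluoromethyl group is needed for the gain also stays open.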